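The source may report more compounds than this note shows. Statements on the series, on what has been measured and on what is new or still open speak of the compounds shown alone.

Measured so far:
- compound 1 `COc1ccc(C(=O)/C=C/c2ccc(F)cc2)c(O)c1` — 60%
- compound 2 `COc1ccc(/C=C/C(=O)c2ccco2)cc1Br` — 8.8%
- compound 3 `COc1ccc(/C=C/C(=O)c2ccc(O)cc2)cc1Br` — 6.6%

In an assay on isolated protein for inhibition of DNA topoisomerase 1 (Homo sapiens), tested at 20 uM (a higher number here means a stronger effect of the compound at the concentration tested, a lower number a weaker effect), compound 2 gives 8.8%, the second highest of the three numbers shown. Compound 3 gives 6.6%, which lies within the scatter of the number for compound 2, so the two are not told apart. Going by the values given here, compound 1 gives 60%, the furthest from compound 2 and beyond the scatter; the two structures differ in more than one place, so no single step between them is computed. Among the compounds with values here, no pair of measured compounds differs in one place, and so no step is available to guide the next compound.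

Compound 4 `COc1ccc(/C=C/C(=O)c2cccs2)cc1Br` is not yet measured. It differs from compound 2 in one place: thiophen-2-yl in place of furan-2-yl on a carbonyl carbon. Within the data shown here, with no comparable step among the measured compounds, the size of the step in this assay is open; the expectation is a step that stays within the scatter, with no direction claimed beyond it. The expected step from compound 2 to compound 4 is a number 3.2 percentage points higher from compound 2 to compound 4 (within the scatter). For compound 4 the estimate is 12%, expected between 3% and 28%.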

Compound 4, a percentage reported as inhibition, at one concentration (the size of the read-out at that concentration, not a potency): 2.1%
For compound 4 the middle estimate is 9.9 percentage points above the measured one, and the stated range ends above it.
By their numbers in this assay, from the lowest: compounds 4, 3 and 2 (each within the scatter of the next); then compound 1.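

In this assay, going by these compounds alone, the first readable step, a number 6.7 percentage points lower from compound 2 to compound 4 (within the scatter), stays within the scatter, so thiophen-2-yl in place of furan-2-yl on a carbonyl carbon does not tell the two compounds apart. This exchange of one five-membered aromatic ring for another therefore gives no detectable change at this position, and compound 4 cannot be ranked against compound 2. No measured evidence bears on this result.

From the compounds shown here alone, whether any other group at this position can produce a step beyond the scatter remains open, for example a ring carrying an amine or a carboxylic acid. Also open is which structural difference accounts for the much higher value of compound 1, as it differs from the others in more than one place.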